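This account rests on a few compounds, and the source may have more. Where it says the series, first, only, none or still open, it means among the compounds named here.

The measured compounds and their values:

Compound 1 `NS(=O)(=O)c1ccc2nc(N3N=C(c4ccc(Br)cc4)CC3c3ccc(F)cc3)sc2c1` — 14%
Compound 2 `Cc1ccc(C2CC(c3ccc(Cl)cc3)=NN2c2nc3ccc(S(N)(=O)=O)cc3s2)cc1` — 14%
Compound 3 `Cc1ccc(C2CC(c3ccc(Br)cc3)=NN2c2nc3ccc(S(N)(=O)=O)cc3s2)cc1` — 14%

All three share one core and differ only in the two aromatic rings carried on the five-membered non-aromatic ring. In a functional assay on the whole organism (strain Wistar) for inhibition, with Rattus norvegicus as the target, read by paw edema, with stated times of 1 h and 5 h, at a dose of 20 mg/kg by the oral route (on this read-out lower numbers stand for less inhibition and higher numbers for more inhibition at the one dose given (going by the name of the read-out)), compound 2 gives 14%, level with compound 1 and compound 3 at the digits shown. The two measured steps bear this out: no change at the digits printed from compound 1 to compound 3 (within the scatter) and no change at the digits printed from compound 2 to compound 3 (within the scatter). Neither exchange moved the read-out beyond the scatter.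

Compound 4 `NS(=O)(=O)c1ccc2nc(N3N=C(c4ccc(Cl)cc4)CC3c3ccccc3Cl)sc2c1` has not yet been measured. It differs from compound 2 by 2-chlorophenyl in place of 4-methylphenyl on a saturated ring carbon. The step from compound 1 to compound 3 is the one that touches the same ring, the ring on the saturated ring carbon, and it gave no change; the step from compound 2 to compound 3 touched the other ring and also gave no change. Among the measured compounds shown here, no measured step places a 2-chlorophenyl group on that carbon, so the data give no direct guide to this particular ring. On what is known, no step beyond the scatter is expected for compound 4, with no change at the digits printed from compound 2 to compound 4 (within the scatter) as the expected step. Compound 4 is therefore estimated at 14%, within a range from 5% to 25%.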

Compound 4, a percentage reported as inhibition, in the whole organism at one dose (the size of the read-out at that dose, not a potency): 14%
Compound 4: the middle estimate sits on the measured number at the digits printed, and the stated range covers the measured number.
By their numbers in this assay, from the lowest: compounds 1, 2, 3 and 4 (each within the scatter of the next).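

In this assay, 2-chlorophenyl in place of 4-methylphenyl on the saturated ring carbon gave no change at the digits printed from compound 2 to compound 4 (within the scatter). Among the compounds shown here, the earlier step on this ring exchanged only one substituent for another, whereas here both the substituent and its place on the ring differ, and the read-out still stays within the scatter, so the level seen for the earlier compounds now extends to a chlorine-bearing ring on this carbon. No measurement bears on why this exchange leaves the read-out where it is.

From the compounds shown here alone, all four compounds carry an aromatic ring of carbon only on this saturated ring carbon, so it remains open whether an amine or a carboxylic acid on that ring, or a longer chain such as hexyl in place of the ring, would take the read-out beyond the scatter. The sulfonamide is also common to all four, which leaves open what a carboxylic acid in its place would do to the inhibition of paw edema at this one dose.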